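From methylsulfanyl to methylsulfonyl in compound 4

The source may hold more compounds than are shown below. What is called first, only, known or untested is meant among the compounds shown, and "the series" means these compounds.

Results in a functional assay (Homo sapiens) for inhibition (a lower number here means a stronger inhibitor, a higher number a weaker inhibitor), so far:
Compound 1 `CS(=O)(=O)c1ccc(CSc2nc(-c3ccc(Cl)cc3)c(-c3ccncc3)[nH]2)cc1` gives 320 nM
Compound 2 `CS(=O)(=O)c1ccc(CSc2nc(-c3ccc(Br)cc3)c(-c3ccncc3)[nH]2)cc1` gives 640 nM
Compound 3 `CSc1ccc(CSc2nc(-c3ccccc3)c(-c3ccncc3)[nH]2)cc1` gives 72500 nM

Compound 3 has the highest number of the three, which makes it the weakest inhibitor, well beyond the scatter from both others. Compound 4 `CS(=O)(=O)c1ccc(CSc2nc(-c3ccccc3)c(-c3ccncc3)[nH]2)cc1` has not yet been measured. It carries methylsulfonyl in place of methylsulfanyl on an aromatic carbon and is otherwise the same as compound 3. For the measured compounds named here, no measured step isolates this change. Going by the values given here, the only measured step, a 2.0-fold higher number from compound 1 to compound 2 (0.30 log units; within the scatter), swaps one halogen for another and leaves the sulfur group untouched. Compounds 1 and 2 both carry methylsulfonyl, but each also has a halogen that compound 4 lacks, so their numbers are only an indirect guide. Even so, compound 1 at 320 nM and compound 2 at 640 nM point towards a much lower number. The expected change is a 48-fold lower number from compound 3 to compound 4 (1.68 log units; beyond the scatter) in this assay, well beyond the scatter. For compound 4 the estimate is 1500 nM, with an expected range of 300 nM to 10000 nM.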

Compound 4, half-maximal inhibitory concentration: 1700 nM
Estimate against measurement, compound 4: 1.1-fold (0.05 log units) below; the measured number falls inside the stated range.
By their numbers in this assay, from the lowest: compounds 1 and 2 (each within the scatter of the next); then compound 4; then compound 3.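

In this assay, for the compounds shown here, methylsulfonyl in place of methylsulfanyl on the aromatic carbon, para to a large group, gives a 43-fold lower number from compound 3 to compound 4 (1.63 log units; beyond the scatter) and is the first measurement of this change with nothing else in the structure altered. Going by these compounds alone, the same compound 4 also shows for the first time what a halogen on the other aromatic ring contributes: hydrogen in place of bromo gives a 2.7-fold higher number from compound 2 to compound 4 (0.42 log units; beyond the scatter) and hydrogen in place of chloro gives a 5.3-fold higher number from compound 1 to compound 4 (0.73 log units; beyond the scatter). Both halogen steps are modest, whereas the sulfur step is large, so among these compounds the sulfur group has the bigger say.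

Nothing available explains the size of the sulfur step. On these data alone, whether a carboxylic acid or an amine at the same position would match methylsulfonyl, and whether the halogen steps hold when methylsulfanyl is present, remain open.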